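This account rests on a few compounds, and the source may have more. Where it says the series, first, only, none or still open, it means among the compounds named here.

Compound 1 `CC(C)(O)Cn1nc(-c2cc(C3CC3)on2)c2c(N)ncnc21`: in an ADME assay on BaF3 cells (Mus musculus) for cytotoxicity, read by MTT assay, with a stated time of 48 h (a lower number here means a stronger inhibitor of growth, a higher number a weaker inhibitor of growth), compound 1 gives > 10000 nM, which is a limit of the assay.
Compound 2 `CCCCCCCn1nc(-c2cc(C3CC3)on2)c2c(N)ncnc21`: compound 2 gives > 10000 nM, again a limit.
Compound 3 `Cn1nc(-c2cc(C3CC3)on2)c2c(N)ncnc21`: compound 3 gives > 10000 nM, also a limit.

Compound 3 therefore stands only at a limit, and so do both of its neighbours: the limit of > 10000 nM in this assay, at which 3 of the 3 values shown sit. The steps a step that the two limits leave unreadable from compound 1 to compound 3, a step that the two limits leave unreadable from compound 2 to compound 3 and a step that the two limits leave unreadable from compound 1 to compound 2 cannot be read, as both ends of each sit at the limit. Compound 4 `Nc1ncnc2c1c(-c1cc(C3CC3)on1)nn2C1CCOCC1` differs from compound 3 as follows: oxan-4-yl in place of methyl on an aromatic nitrogen. The three measured compounds vary the group bound to an aromatic nitrogen without any value leaving the limit, so the step that the limit leaves unreadable from compound 3 to compound 4 in this assay is expected to be none beyond the scatter. Compound 4 is estimated to give 15000 nM, with a range from 7000 nM to 50000 nM.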

Compound 4, concentration for 50% growth inhibition: > 10000 nM
Compound 4 ended at the assay's limit; the forecaster's own chance of this, stated with the estimate: 80%; the middle value is on the limit's open side.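

The steps to compound 4 from compound 1, compound 2 and compound 3 cannot be read, because all four compounds sit at one limit: the limit of > 10000 nM in this assay, at which 4 of the 4 values shown sit.

The compounds shown leave open how strongly any of them inhibits growth in this assay, and whether the group on the aromatic nitrogen matters there.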